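Swapping a hydroxylated chain for a furan on the ester

The compounds below may be only part of what the source reports. "The series", "measured", "known", "first", "only" and "open" are said of these compounds alone.

In a functional assay on DU-145 cells (Homo sapiens) for cytotoxicity, read by MTT assay (on this read-out lower numbers stand for stronger inhibition and higher numbers for weaker inhibition), compound 1 (`CCCCC(CC(=O)O[C@H](CC=C(C)C)C1=CC(=O)c2c(O)ccc(O)c2C1=O)OC(C)=O`) gives 67700 nM, compound 2 (`CCC(CO[C@H](CC=C(C)C)C1=CC(=O)c2c(O)ccc(O)c2C1=O)OC(C)=O`) gives 25400 nM and compound 3 (`CCC(C)(O)CC(=O)O[C@H](CC=C(C)C)C1=CC(=O)c2c(O)ccc(O)c2C1=O`) gives 16000 nM. Compound 3 sits at the low end of these numbers, with steps of a 1.6-fold lower number from compound 2 to compound 3 (0.20 log units; within the scatter) and a 4.2-fold lower number from compound 1 to compound 3 (0.63 log units; beyond the scatter). Compound 4 (`CC(C)=CC[C@@H](OC(=O)c1ccoc1)C1=CC(=O)c2c(O)ccc(O)c2C1=O`) carries furan-3-yl in place of 2-hydroxy-2-methylbutyl on a carbonyl carbon. Both measured steps also alter the group at this ester, but neither introduces a ring, so they suggest only a rough size and no direction. The expected change in this assay is therefore small, an estimated 1.1-fold higher number from compound 3 to compound 4 (0.05 log units; within the scatter). Compound 4 is estimated at 18000 nM, within an expected range of 6000 nM to 50000 nM.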

Compound 4, half-maximal inhibitory concentration: > 100000 nM
Compound 4 gave a limit, no number; the forecaster's own chance of this, stated with the estimate: 5%; middle value at least 5.5-fold (0.74 log units) from the limit.
By their numbers in this assay, from the lowest: compounds 3 and 2 (each within the scatter of the next); then compound 1. At a limit, above all of these: compound 4.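

Compound 4 gives a limit of the assay, not a number: the limit of > 100000 nM in this assay, at which 1 of the 4 values shown sits. This ester position is therefore not indifferent to what it carries: furan-3-yl on this carbonyl carbon gives an at least 6.2-fold higher number from compound 3 to compound 4 (0.79 log units; beyond the scatter) and an at least 3.9-fold higher number from compound 2 to compound 4 (0.59 log units; beyond the scatter). Against the weakest earlier compound the result is unsettled, with an at least 1.4-fold higher number from compound 1 to compound 4 (0.16 log units; that floor lies within the scatter).

The change brings in a ring and removes a hydroxyl together, and the compounds shown cannot separate these two differences. On these data alone, a phenyl ring, or a 3-methylbutyl chain without the hydroxyl, on this carbonyl carbon remains untested here.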